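Working notes on compound 2 and the next step

The source may report more compounds than this note shows. Statements on the series, on what has been measured and on what is new or still open speak of the compounds shown alone.

Among the compounds with values here, compound 1 `Fc1ccc2nc(-n3ccnn3)n(C3CC3)c2c1` and compound 2 `Fc1cc2nc(-c3cncnc3C3CC3)n(C3CC3)c2cc1F` are the two compounds measured so far in an assay on cells for inhibition of cytochrome P450 11B2, mitochondrial (Homo sapiens), read by HPLC, with a stated time of 90 min; a lower number here means a stronger inhibitor, a higher number a weaker inhibitor. Compound 1 gives 1060 nM in this assay, and compound 2 gives 172 nM in this assay, the lower of the two numbers; the gap between them lies beyond the scatter. Within the data shown here, the two compounds differ in more than one place, so no single step connects them, and only the two values themselves can be set side by side.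

Compound 3 `CC(F)(F)c1ncncc1-c1nc2cc(F)c(F)cc2n1C1CC1` is the next compound, not yet measured. It differs from compound 2 by 1,1-difluoroethyl in place of cyclopropyl on an aromatic carbon. Among the measured compounds shown here, nothing among the measured compounds shows what this exchange does in this assay, so no step beyond the scatter is expected in either direction. Compound 3 is therefore expected to give about 200 nM in this assay, within 60 nM to 600 nM. The step of a 1.2-fold higher number from compound 2 to compound 3 (0.07 log units; within the scatter) is the one this estimate means.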

Compound 3, half-maximal inhibitory concentration: 50 nM
Estimate against measurement, compound 3: 4.0-fold (0.60 log units) above; measured number outside the range, below it.
By their numbers in this assay, from the lowest: compound 3; then compound 2; then compound 1.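

The number falls a 3.4-fold lower number from compound 2 to compound 3 (0.54 log units; beyond the scatter) in this assay when 1,1-difluoroethyl replaces cyclopropyl on an aromatic carbon, the first single-place step available in this series. The position, on the six-membered aromatic ring with 2 nitrogen and next to the ring nitrogen, therefore responds to the group it carries, and a three-membered carbon ring is not needed there for a number this low. Nothing at hand bears on why the number falls with this exchange.

As far as these compounds go, it remains open whether a trifluoromethyl, a methyl or a methoxy group at the same place would give a lower or a higher number than 1,1-difluoroethyl. From the compounds shown here alone, it is equally open whether this exchange gives a step of similar size when the fluorine atoms on the shared core are changed.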